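Notes on compound 4, derived from compound 2

The source may hold more compounds than are shown below. What is called first, only, known or untested is meant among the compounds shown, and "the series" means these compounds.

Measured in an assay on isolated protein for inhibition of DNA topoisomerase 1 (Homo sapiens), with a stated time of 30 min, tested at 100 uM; on this read-out higher numbers stand for a stronger effect at the one concentration tested and lower numbers for a weaker effect:
compound 1 `Oc1cccc(-c2cc(-c3ccc(Cl)cc3)nc(-c3cccs3)c2)c1` gives 15.1%
compound 2 `Oc1cccc(-c2cc(-c3cccc(Cl)c3)nc(-c3cccs3)c2)c1` gives 7.6%
compound 3 `Oc1ccc(-c2cc(-c3cccc(Cl)c3)nc(-c3cccs3)c2)cc1` gives 52.4%

Compound 2 holds the smallest of the three numbers, though compound 1 lies within the scatter of it, a number 7.5 percentage points lower from compound 1 to compound 2 (within the scatter); only compound 3 stands clearly apart, a number 44.8 percentage points higher from compound 2 to compound 3 (beyond the scatter). Compound 4 `Oc1cccc(-c2cc(-c3ccncc3)nc(-c3cccc(Cl)c3)c2)c1` differs from compound 2 in one place: pyridin-4-yl in place of thiophen-2-yl on an aromatic carbon. Neither measured step touches this position; both move a substituent on one of the two phenyl groups. For the measured compounds named here, no measured step therefore bears on the change, and nothing argues for a shift beyond the scatter in this assay. The expected step is a number 4.4 percentage points higher from compound 2 to compound 4 (within the scatter). Compound 4 is estimated at 12%, with a range from 0% to 35%.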

Compound 4, a percentage reported as inhibition, at one concentration (the size of the read-out at that concentration, not a potency): 0%
The estimate for compound 4 lay 12 percentage points above the measured number; measured number inside the range.
By their numbers in this assay, from the lowest: compounds 4, 2 and 1 (each within the scatter of the next, the first and the last beyond it); then compound 3.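

For the compounds shown here, the first reading at this position, on an aromatic carbon next to the ring nitrogen, is a number 7.6 percentage points lower from compound 2 to compound 4 (within the scatter) in this assay, for pyridin-4-yl in place of thiophen-2-yl. With the 3-hydroxyphenyl group present, this exchange therefore separates the two rings by nothing beyond the scatter, although compound 2 already gives so small a number that little further loss could show. No evidence bears on this result.

On these data alone, whether the same exchange holds beside the 4-hydroxyphenyl group of compound 3, where there is room for a loss to show, remains open. So does the effect of an amine or a carboxylic acid at this position.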